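Swapping the Amide Substituent: What to Expect for Compound 4

The source may report more compounds than this note shows. Statements on the series, on what has been measured and on what is new or still open speak of the compounds shown alone.

Three measured compounds share one core and differ only in the group on the amide nitrogen. Compound 1 `COc1ccc2c(=O)c(/C=C/C(=O)NCc3ccccc3)coc2c1` carries a benzyl group, and in an ADME assay on HepG2 2.2.15 cells (Homo sapiens) for cytotoxicity, read by MTT assay, with stated times of 48 h and 9 days (on this read-out higher numbers stand for lower toxicity in this test and lower numbers for higher toxicity in this test), compound 1 gives 376000 nM. Compound 2 `COc1ccc2c(=O)c(/C=C/C(=O)Nc3ccccc3)coc2c1` carries a phenyl group, and in this assay compound 2 gives 523000 nM; the step of a 1.4-fold higher number from compound 1 to compound 2 (0.14 log units; within the scatter). Compound 3 `COc1ccc(CNC(=O)/C=C/c2coc3cc(OC)ccc3c2=O)cc1` carries a 4-methoxybenzyl group, and in this assay compound 3 gives 43000 nM, the lowest of the three numbers and thus the most toxic in this test; its steps from both others are beyond the scatter, as an 8.7-fold lower number from compound 1 to compound 3 (0.94 log units; beyond the scatter) and a 12-fold lower number from compound 2 to compound 3 (1.09 log units; beyond the scatter) show.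

Compound 4 `COc1ccc2c(=O)c(/C=C/C(=O)Nc3ccccc3C)coc2c1` has not yet been measured. Relative to compound 3 the change is 2-methylphenyl in place of 4-methoxybenzyl on an amide-type nitrogen. Among the measured compounds shown here, the steps that bear on it are the two leading into compound 3, namely a 12-fold lower number from compound 2 to compound 3 (1.09 log units; beyond the scatter) and an 8.7-fold lower number from compound 1 to compound 3 (0.94 log units; beyond the scatter). Compound 2, which also carries a ring on the amide nitrogen, gives 523000 nM in this assay. The number for compound 4 is expected to move back toward that, by a 9.3-fold higher number from compound 3 to compound 4 (0.97 log units; beyond the scatter). In this assay compound 4 is therefore estimated at 400000 nM, with a plausible range from 150000 nM to 900000 nM.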

Compound 4, half-maximal cytotoxic concentration: 59700 nM
Estimate against measurement, compound 4: 6.7-fold (0.83 log units) above; the measured number lies below the stated range.
By their numbers in this assay, from the lowest: compounds 3 and 4 (each within the scatter of the next); then compounds 1 and 2 (each within the scatter of the next).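

The new result shows that the phenyl group on the amide-type nitrogen is sensitive to a very small addition: in this assay, adding a methyl group to that ring gives an 8.8-fold lower number from compound 2 to compound 4 (0.94 log units; beyond the scatter) and so makes the compound clearly more toxic in this test. Compound 4 also separates from the benzyl compound, with a 6.3-fold lower number from compound 1 to compound 4 (0.80 log units; beyond the scatter) as the step, yet it stays level with the methoxy compound, with a 1.4-fold higher number from compound 3 to compound 4 (0.14 log units; within the scatter) as the step, even though 2-methylphenyl carries no oxygen and 4-methoxybenzyl does. Among these four compounds, then, the two with a substituted ring give lower numbers than the two with an unsubstituted ring, so an oxygen in the group is not needed for a low number. No measurement available here explains why either added group has this effect.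

The compounds shown leave open whether a different group on the same ring, such as a hydroxyl or an amine, would lower the number as well. They also leave open whether 2-methylbenzyl would behave like 2-methylphenyl.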